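The compounds below may be only part of what the source reports. "The series", "measured", "known", "first", "only" and "open" are said of these compounds alone.

For the measured compounds named here, in an ADME assay on NHDF cells (Homo sapiens) for cytotoxicity, read by MTT assay, with a stated time of 72 h (a higher number here means a weaker inhibitor, a lower number a stronger inhibitor), compound 1 (`COc1ccc(/C=C2\CCC/C(=C\c3ccccc3Br)C2=O)cc1OC`) gives 21800 nM and compound 2 (`COc1ccc(/C=C2\CCC/C(=C\c3ccc(OC)c(OC)c3)C2=O)cc1`) gives 30900 nM within the scatter of each other, so compound 2 stands level with compound 1 as one of only two measured members. The next change leads from compound 2 to compound 3 (`COc1ccc(/C=C2\CCC/C(=C\c3ccc(O)cc3)C2=O)cc1OC`) and reads hydrogen in place of methyl on an oxygen on an aromatic ring with hydrogen in place of methyl on an oxygen on an aromatic ring, that is methoxy to hydroxy. Going by the values given here, no measured step covers this exchange. Given the only measured step, a 1.4-fold higher number from compound 1 to compound 2 (0.15 log units; within the scatter) for a different exchange, no step beyond the scatter is expected in this assay and no direction is favoured. The estimated move is a 1.2-fold lower number from compound 2 to compound 3 (0.07 log units; within the scatter) and is expected to stay within the scatter. Compound 3 is expected at 26000 nM with an estimated range from 11000 nM to 60000 nM for now.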

Compound 3, half-maximal inhibitory concentration: 26100 nM
For compound 3 the middle estimate is 1.0-fold (0.00 log units) below the measured one; low and high end bracket the measured number.
By their numbers in this assay, from the lowest: compounds 1, 3 and 2 (each within the scatter of the next).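

In this assay the exchange of methoxy to hydroxy gives a 1.2-fold lower number from compound 2 to compound 3 (0.07 log units; within the scatter) and the two compounds stand level, so this oxygen on an aromatic ring, not covered by the earlier pair, tolerates the loss of its methyl within the scatter in this read-out. The exchange of 2-bromophenyl for 4-hydroxyphenyl gives a 1.2-fold higher number from compound 1 to compound 3 (0.08 log units; within the scatter) and also stays within the scatter, so all three compounds sit level here, with no order among them. Nothing on hand gives a reason for this flat reading.

From the compounds shown here alone, an amine or a carboxylic acid in place of the hydroxy remains open, as does a longer chain on that oxygen. In this assay the three compounds also leave open whether any change to the shared core moves the number beyond the scatter.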